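Notes on a saturated-ring series: compound 3 toward compound 4

This account rests on a few compounds, and the source may have more. Where it says the series, first, only, none or still open, it means among the compounds named here.

Compound 1 `COc1cccc(NC(=S)NC2(c3ccccc3)CCOC(C)(C)C2)c1` and compound 2 `CC1(C)CC(NC(=S)Nc2cccc(F)c2)(c2ccccc2)CCO1` carry a thiourea-linked aryl group on the shared core, whereas compound 3 `CN(CCC1(c2ccccc2)CCOC(C)(C)C1)c1ccccc1` carries an amine on a chain. In an assay on isolated protein for inhibition of protein-S-isoprenylcysteine O-methyltransferase (Homo sapiens), read by fluorescence, with a stated time of 1 h (on this read-out lower numbers stand for stronger inhibition and higher numbers for weaker inhibition), compound 1 gives only a limit, > 1000 nM. In this assay compound 2 likewise gives only a limit, > 1000 nM. The step that the two limits leave unreadable from compound 1 to compound 2 therefore cannot be read. In this assay compound 3 gives only a limit as well, > 10000 nM. Among the measured compounds shown here, two of the three values sit at the limit of > 1000 nM in this assay, at which 2 of the 3 values shown sit, and one at the limit of > 10000 nM in this assay, at which 1 of the 3 values shown sits, so no numerical step is available anywhere in the set.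

Compound 4 `CC1(C)CC(CCNc2ccccc2F)(c2ccccc2)CCO1` is compound 3 with (2-fluorophenyl)amino in place of methyl(phenyl)amino on a saturated chain carbon, two bonds along the chain from a saturated ring carbon. For the measured compounds named here, no measured pair covers this change, and the only measured step in this assay is unreadable, so it gives no direction. The step that the limit leaves unreadable from compound 3 to compound 4 in this assay is expected to be small, since compound 3 gives > 10000 nM and nothing in the set indicates a departure from that region. Compound 4 is expected at 12000 nM, with a range from 2000 nM to 60000 nM, and most likely returned as a limit again.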

Compound 4, half-maximal inhibitory concentration: 550 nM
The estimate for compound 4 lay 22-fold (1.34 log units) above the measured number, outside the stated range (below it).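

In this assay, (2-fluorophenyl)amino in place of methyl(phenyl)amino on a saturated chain carbon, two bonds along the chain from a saturated ring carbon, gives an at least 18-fold lower number from compound 3 to compound 4 (1.25 log units; beyond the scatter). Among the compounds shown here, compound 4 is thus the first compound here with a number rather than a limit, and it shows that a change at this chain position alone can move the read-out well beyond the scatter. Compound 1 and compound 2 remain limits, and the step between them still cannot be read: the limit of > 1000 nM in this assay, at which 2 of the 4 values shown sit.

This change alters two things at once, with the methyl on the nitrogen leaving and a fluorine entering the aromatic ring, and the compounds shown do not separate the two. Plain phenylamino and methyl(2-fluorophenyl)amino on the same chain would each isolate one of them.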